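The source may report more compounds than this note shows. Statements on the series, on what has been measured and on what is new or still open speak of the compounds shown alone.

Measured so far: compound 1 `C[C@@H](O)[C@H]1C(=O)N2C(C(=O)OCOC(=O)OC3CCCCC3)=C(S[C@@H]3CN[C@H](C(=O)Nc4cccc(C(=O)O)c4)C3)[C@H](C)[C@H]12` with 0%; compound 2 `C[C@@H](O)[C@H]1C(=O)N2C(C(=O)OCOC(=O)OC3CCCCC3)=C(S[C@@H]3CN[C@H](C(=O)Nc4cccc(C(=O)OCOC(=O)OC5CCCCC5)c4)C3)[C@H](C)[C@H]12` with 10%.

In an ADME assay on a cell-free system (plasma, Rattus norvegicus) for metabolic stability, read by LC-MS, with a stated time of 60 min, at 37 degrees C, tested at 50 uM (on this read-out lower numbers stand for a less stable compound and higher numbers for a more stable compound), compound 1 stands lowest of the two numbers; its nearest neighbour is compound 2, and a number 10 percentage points higher from compound 1 to compound 2 (within the scatter). Compound 3 `C[C@@H](O)[C@H]1C(=O)N2C(C(=O)OCC(F)(F)F)=C(S[C@@H]3CN[C@H](C(=O)Nc4cccc(C(=O)O)c4)C3)[C@H](C)[C@H]12` differs from compound 1 as follows: trifluoromethyl in place of (cyclohexyloxycarbonyl)oxy on a saturated chain carbon bound to an oxygen next to a carbonyl group. Within the data shown here, no measured step alters this position; the one step, from compound 1 to compound 2, concerns another place and stays within the scatter, so it does not bear on the change. The expectation therefore rests on the change itself and stays wide. For compound 3 a step of a number 55 percentage points higher from compound 1 to compound 3 (beyond the scatter) is expected, estimated at 55% with a range from 15% to 95%.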

Compound 3, percent of the compound remaining: 7%
The estimate for compound 3 lay 48 percentage points above the measured number; the measured number lies below the stated range.
By their numbers in this assay, from the lowest: compounds 1, 3 and 2 (each within the scatter of the next).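

In this assay, trifluoromethyl in place of (cyclohexyloxycarbonyl)oxy gives a number 7 percentage points higher from compound 1 to compound 3 (within the scatter) and so leaves the read-out unchanged within the scatter. Among these compounds, the first measured change at this position therefore shows that removing the six-membered ring and the carbonate oxygens does not, in this pair, separate the two compounds. Nothing available explains this result.

Still open, from the compounds shown here alone, is whether any group at this position gives a number beyond the scatter. A nitrile or a longer alkyl chain in place of trifluoromethyl would test this.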